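From Methyl to Trifluoromethyl at an Assay Limit

The compounds below may be only part of what the source reports. "The series", "measured", "known", "first", "only" and "open" are said of these compounds alone.

Measured compounds in a functional assay on P388 cells (Mus musculus) for inhibition (on this read-out lower numbers stand for stronger inhibition and higher numbers for weaker inhibition), are as follows.
- Compound 1 `COc1cccc(/C=C\c2ccc3ccccc3c2)c1` gives 1920 nM as a number
- Compound 2 `Cc1ccc(/C=C/c2ccc3ccccc3c2)cc1` gives > 5000 nM as a limit
- Compound 3 `Cc1ccc(/C=C\c2ccc3ccccc3c2)cc1` gives > 5000 nM as a limit

In this assay compound 3 stands at > 5000 nM and this is a limit, not a number. Compound 4 `FC(F)(F)c1ccc(/C=C\c2ccc3ccccc3c2)cc1` has trifluoromethyl in place of methyl on an aromatic carbon, para to a large group, as counted in trifluoromethyl in place of methyl on an aromatic carbon and nothing else differs. Among the compounds with values here, the only measured step is a step that the two limits leave unreadable from compound 2 to compound 3 and it offers no size to carry over. Within the data shown here, no measured step covers this replacement, so no clear shift is expected and compound 4 is expected to remain near the limit. The expected change is a step that the limit leaves unreadable from compound 3 to compound 4 and it is only an estimate. For compound 4 the estimated value is 6000 nM with an expected range from 2000 nM to 20000 nM in this assay as the read-out.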

Compound 4, half-maximal inhibitory concentration: > 5000 nM
Compound 4: only a limit was reported; the forecaster's own chance of this, stated with the estimate: 65%; the middle value is on the limit's open side.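

Compound 3 and compound 4 both give only a limit in this assay, so the step between them cannot be read. The compounds shown leave open whether trifluoromethyl in place of methyl changes inhibition at all.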